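A Thiophene in Place of the Dichlorophenyl Sulfone

The source may hold more compounds than are shown below. What is called first, only, known or untested is meant among the compounds shown, and "the series" means these compounds.

Among the measured compounds shown here, compound 2 `CN(C)CCn1cc(S(=O)(=O)c2c(Cl)cccc2Cl)c2cccnc21` gives 9 nM in an assay on HeLa cells for displacement of a labelled ligand from 5-hydroxytryptamine receptor 6 (Homo sapiens) (on this read-out lower numbers stand for stronger inhibition and higher numbers for weaker inhibition), the lowest of the two numbers so far; its only measured neighbour, compound 1 `CN(C)CCn1cc(S(=O)(=O)c2ccccc2)c2cccnc21`, gives 23 nM in this assay. For the measured compounds named here, the single step between them, a 2.6-fold lower number from compound 1 to compound 2 (0.41 log units; beyond the scatter), is modest. Compound 3 `CN(C)CCn1cc(S(=O)(=O)c2cccs2)c2cccnc21` is not yet measured; it differs from compound 2 in that (thiophen-2-yl in place of 2,6-dichlorophenyl on a sulfonyl sulfur). Going by the values given here, no measured compound carries a thiophen-2-yl group, so the only step that bears on this change is the one from compound 1 to compound 2, and compound 3 gives up the chlorine substituents that marked that step. Compound 3 is therefore expected to fall back to roughly the level of compound 1. The estimated step is a 2.2-fold higher number from compound 2 to compound 3 (0.35 log units; beyond the scatter), which stays close to the scatter. Compound 3 is estimated at 20 nM in this assay, with a range from 7 nM to 60 nM.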

Compound 3, inhibition constant: 15 nM
Compound 3: middle estimate off by 1.3-fold (0.12 log units), on the high side, and the stated range covers the measured number.
By their numbers in this assay, from the lowest: compounds 2, 3 and 1 (each within the scatter of the next, the first and the last beyond it).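

In this assay, the sulfonyl sulfur accepts a five-membered aromatic ring as well as a six-membered one: thiophen-2-yl in compound 3 lies within the scatter of both 2,6-dichlorophenyl (a 1.7-fold higher number from compound 2 to compound 3 (0.22 log units; within the scatter)) and phenyl (a 1.5-fold lower number from compound 1 to compound 3 (0.19 log units; within the scatter)). Compound 3 therefore cannot be grouped with either compound 1 or compound 2, even though those two stand apart (a 2.6-fold lower number from compound 1 to compound 2 (0.41 log units; beyond the scatter)), and a number within the scatter of compound 2 does not require the two chlorine atoms. Nothing measured here explains how these groups compare.

From the compounds shown here alone, whether a chlorine on the thiophen-2-yl ring would give a step like the one seen with 2,6-dichlorophenyl stays open. So does how a furan-2-yl or pyridinyl group would read on the same sulfonyl sulfur.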